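The source may hold more compounds than are shown below. What is called first, only, known or untested is meant among the compounds shown, and "the series" means these compounds.

In an in vitro functional assay on HEK293 cells for antagonist activity at melanin-concentrating hormone receptor 1 (Homo sapiens) (on this read-out lower numbers stand for smaller maximal responses and higher numbers for larger maximal responses), the measured compounds stand as follows:

compound 1, `Cc1ccc(CN2CCC(NC(=O)NCc3ccc(-c4cccc(C#N)c4)cc3)CC2)cc1`, 98%
compound 2, `Cc1ccc(CN2CCC(NC(=O)NCc3ccc(-c4ccccc4)cc3)CC2)cc1`, 124%
compound 3, `Cc1ccc(CN2CCC(CCN(Cc3ccc(-c4cccc(C#N)c4)cc3)C(=O)NC(C)(C)CO)CC2)cc1`, 99.3%

Compound 1 and compound 2 differ in one place, (hydrogen in place of cyano on an aromatic carbon), and in this assay that gave a number 26 percentage points higher from compound 1 to compound 2 (beyond the scatter). Compound 4, `Cc1ccc(CN2CCC(CCN(Cc3ccc(-c4ccccc4)cc3)C(=O)NC(C)(C)CO)CC2)cc1`, stands to compound 3 exactly as compound 2 stands to compound 1: hydrogen in place of cyano on an aromatic carbon. The change is the same, at the same kind of place, and it appears twice among these compounds. How the core of compound 3 differs from the core of compound 1 is not broken down here. Because the earlier step is a number 26 percentage points higher from compound 1 to compound 2 (beyond the scatter), a step of similar size, a number 20.7 percentage points higher from compound 3 to compound 4 (beyond the scatter), is expected from the same change here. Compound 4 is therefore estimated at 120%, between 102% and 138%.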

Compound 4, largest response reached (reported as Imax), in percent of the reference or control that the assay uses: 105%
The estimate for compound 4 lay 15 percentage points above the measured number, within the range that was stated.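

Hydrogen in place of cyano gave a number 5.7 percentage points higher from compound 3 to compound 4 (within the scatter) in this assay and so did not repeat the step seen on the core of compound 1, as the two steps side by side show: the same change on two cores in this assay, a number 26 percentage points higher (beyond the scatter) from compound 1 to compound 2 and a number 5.7 percentage points higher (within the scatter) from compound 3 to compound 4, 20.3 percentage points apart, beyond the scatter of two such steps

In these two pairs, then, the size of the step changed with the core, and the earlier step alone would not have given the later one. This does not show which part of the core matters, and two pairs set no rule for the whole series.

As far as these compounds go, only cyano and hydrogen appear at this place on the aromatic ring, so the outcome with a fluorine atom, a methoxy group or a carboxylic acid there stays open on both cores. Also open is whether a core with a longer chain would behave like either core shown.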